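Amide for Sulfonamide on a Shared Biaryl Core

The source may report more compounds than this note shows. Statements on the series, on what has been measured and on what is new or still open speak of the compounds shown alone.

Measured compounds:
compound 1, `CCOC(=O)c1cccc(-c2ccc(O)cc2)c1`, gives 77%
compound 2, `CCNS(=O)(=O)c1cccc(-c2ccc(OCC)cc2)c1`, gives 46%

Of the compounds shown here, two have been measured in an assay on COS-7 cells for inhibition of patatin-like phospholipase domain-containing protein 2 (Mus musculus), tested at 200 uM; a lower number here means less inhibition, a higher number more inhibition at the concentration tested (going by the name of the read-out). Compound 1 reaches 77%, while compound 2 gives 46%. For the measured compounds named here, compound 2 therefore stands lowest of the two numbers, and its only neighbour, compound 1, lies above it by a gap that is beyond the usual scatter. The two compounds differ in more than one place, so nothing can be said about which part of the structure accounts for that gap.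

Compound 3, `CCOc1ccc(-c2cccc(C(=O)NC)c2)cc1`, has not yet been measured. It departs from compound 2 in a single exchange: methylcarbamoyl in place of ethylsulfamoyl on an aromatic carbon. Going by the values given here, no measured pair shows this exchange, so there is no step of known size to lean on. Among the compounds with values here, the account expects an upward step in this assay from compound 2, of moderate size and likely beyond the scatter, because compound 1, the only other compound carrying a carbonyl-containing group on that ring, gives 77%; the expected step is a number 14 percentage points higher from compound 2 to compound 3 (beyond the scatter). Compound 3 is accordingly estimated at 60%, within a range from 35% to 85%.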

Compound 3, a percentage reported as inhibition, at one concentration (the size of the read-out at that concentration, not a potency): 40%
Compound 3: the middle estimate sits 20 percentage points above what was measured; the range from low to high includes it.
By their numbers in this assay, from the lowest: compounds 3 and 2 (each within the scatter of the next); then compound 1.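

In this assay, putting methylcarbamoyl in place of ethylsulfamoyl on an aromatic carbon, meta to a group of 9 heavy atoms, amounts to a number 6 percentage points lower from compound 2 to compound 3 (within the scatter). For the compounds shown here, this is the first comparison in which only one place differs, and it shows that a group of 4 heavy atoms can stand where one of 6 stood, with a carbonyl instead of the sulfonyl, without a read-out difference beyond the scatter. No measurement shown offers an explanation for this result.

From the compounds shown here alone, compound 1 still differs from compound 2 and compound 3 in more than one place, so it remains open whether the gap to compound 1 belongs to the group on this carbon or to a change elsewhere on the shared core. Also open, going by these compounds, is how this position would respond to a carboxylic acid, a primary amine or a longer chain on the amide nitrogen, and how a hydroxyl group would read on the core of compound 3 with the methylcarbamoyl group kept in place.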